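This account rests on a few compounds, and the source may have more. Where it says the series, first, only, none or still open, it means among the compounds named here.

Measured so far in a functional assay on KB cells (Homo sapiens) for antiproliferative activity, read by MTT assay, with a stated time of 72 h; on this read-out lower numbers stand for stronger inhibition and higher numbers for weaker inhibition:
- compound 1 `CCC(=O)N(C)c1ccc2[nH]c(-c3n[nH]c4ccccc34)cc2n1`: 9300 nM
- compound 2 `CN(C(=O)CCc1ccccc1)c1ccc2[nH]c(-c3n[nH]c4ccccc34)cc2n1`: 7380 nM
- compound 3 `CN(C(=O)c1ccc(Br)cc1)c1ccc2[nH]c(-c3n[nH]c4ccccc34)cc2n1`: 1780 nM

Compound 3 gives the lowest number of the three in this assay, its nearest neighbour being compound 2 and the furthest compound 1. The steps leading to it were a 5.2-fold lower number from compound 1 to compound 3 (0.72 log units; beyond the scatter) and a 4.1-fold lower number from compound 2 to compound 3 (0.62 log units; beyond the scatter), while a 1.3-fold lower number from compound 1 to compound 2 (0.10 log units; within the scatter) stayed within the scatter; all three steps vary only the group on the carbonyl carbon, the carbonyl itself being kept throughout.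

Compound 4 `CN(c1ccc2[nH]c(-c3n[nH]c4ccccc34)cc2n1)S(=O)(=O)c1ccccc1` departs from compound 3 by phenylsulfonyl in place of (4-bromophenyl)carbonyl on a nitrogen on an aromatic ring. Among the compounds with values here, no measured step replaces the carbonyl with a different linker, so the steps at hand bear only indirectly: they show that an aromatic ring on the acyl side gave the lower numbers, and compound 4 keeps such a ring but loses the bromine and the carbonyl. Any direction is therefore uncertain; the expected step is a 1.7-fold higher number from compound 3 to compound 4 (0.23 log units; within the scatter), read as no confident change beyond the scatter. Compound 4 is estimated at 3000 nM, within a range from 800 nM to 12000 nM.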

Compound 4, half-maximal inhibitory concentration: 2400 nM
The estimate for compound 4 lay 1.3-fold (0.10 log units) above the measured number, within the range that was stated.
By their numbers in this assay, from the lowest: compounds 3 and 4 (each within the scatter of the next); then compounds 2 and 1 (each within the scatter of the next).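

At the nitrogen on an aromatic ring, the linker can change from carbonyl to sulfonyl in this assay without a readable shift: phenylsulfonyl matches (4-bromophenyl)carbonyl (a 1.3-fold higher number from compound 3 to compound 4 (0.13 log units; within the scatter)), even though the bromine is lost as well. The sulfonyl compound also keeps the advantage over both saturated-chain acyl groups (a 3.1-fold lower number from compound 2 to compound 4 (0.49 log units; beyond the scatter); a 3.9-fold lower number from compound 1 to compound 4 (0.59 log units; beyond the scatter)), so the lower numbers in this small set do not depend on a carbonyl. Nothing at hand gives a reason for these numbers.

A benzoyl group or a 4-bromophenylsulfonyl group on the same nitrogen would separate the contribution of the bromine from that of the linker. Also open, on these data alone, is whether a methanesulfonyl group, which carries no aromatic ring, or a urea linker would hold these numbers.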